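Swapping Trifluoromethyl for Isopropoxy on the Piperidine Ring

The source may report more compounds than this note shows. Statements on the series, on what has been measured and on what is new or still open speak of the compounds shown alone.

Compound 1 `Cc1ccc(Cl)cc1Nc1nc(C(F)(F)F)ccc1CNC(=O)C(C)c1ccc(NS(C)(=O)=O)c(F)c1`: in a functional assay on CHO-K1 cells for antagonist activity at transient receptor potential cation channel subfamily V member 1 (Homo sapiens), read by FLIPR (on this read-out higher numbers stand for weaker inhibition and lower numbers for stronger inhibition), compound 1 gives 14 nM.
Compound 2 `CC(C(=O)NCc1ccc(C(F)(F)F)nc1N(C)c1ccccc1)c1ccc(NS(C)(=O)=O)c(F)c1`: compound 2 gives 0.9 nM.
Compound 3 `CC(C(=O)NCc1ccc(C(F)(F)F)nc1N1CCC(C(F)(F)F)CC1)c1ccc(NS(C)(=O)=O)c(F)c1`: compound 3 gives 0.6 nM.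

Compound 3 stands at the lowest number of the three, but compound 2 lies within the scatter of it, so the two cannot be ranked; only compound 1 is clearly set apart, as the step of a 23-fold lower number from compound 1 to compound 3 (1.37 log units; beyond the scatter) shows.

Compound 4 `CC(C)OC1CCN(c2nc(C(F)(F)F)ccc2CNC(=O)C(C)c2ccc(NS(C)(=O)=O)c(F)c2)CC1` differs from compound 3 in one place: isopropoxy in place of trifluoromethyl on a saturated ring carbon. Among the compounds with values here, no measured step touches this part of the molecule. The steps of a 16-fold lower number from compound 1 to compound 2 (1.19 log units; beyond the scatter) and a 23-fold lower number from compound 1 to compound 3 (1.37 log units; beyond the scatter) concern the group on the aromatic carbon, and a 1.5-fold lower number from compound 2 to compound 3 (0.18 log units; within the scatter) shows that two quite different groups there give numbers within the scatter. Nothing measured speaks to a substituent on the saturated ring itself, so the expectation rests on the change being remote from the part that moved the numbers. For compound 4 the step of a 1.7-fold higher number from compound 3 to compound 4 (0.22 log units; within the scatter) is expected, with no change beyond the scatter. Compound 4 is therefore estimated at 1 nM, between 0.3 nM and 4 nM.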

Compound 4, inhibition constant: 3 nM
Beside the measured number, compound 4's estimate is 3.0-fold (0.48 log units) below it, and the stated range covers the measured number.
By their numbers in this assay, from the lowest: compounds 3 and 2 (each within the scatter of the next); then compound 4; then compound 1.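

In this assay, within the data shown here, the group on this saturated ring carbon, three ring bonds from the ring nitrogen, turns out to matter: isopropoxy in place of trifluoromethyl gives a 5.0-fold higher number from compound 3 to compound 4 (0.70 log units; beyond the scatter) in the first measured change at this position. The 4-isopropoxypiperidin-1-yl group also no longer matches methyl(phenyl)amino, as a 3.3-fold higher number from compound 2 to compound 4 (0.52 log units; beyond the scatter) shows, although 4-(trifluoromethyl)piperidin-1-yl could not be told apart from it. It still stands clear of (5-chloro-2-methylphenyl)amino, with a 4.7-fold lower number from compound 1 to compound 4 (0.67 log units; beyond the scatter) on the side of stronger inhibition.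

From the compounds shown here alone, whether an amine, a carboxylic acid or a longer alkoxy chain on this ring carbon would give a number closer to that of compound 3 or further from it stays open. Why isopropoxy gives a higher number than trifluoromethyl also stays open, with nothing at hand that bears on it.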